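A Dichlorophenyl Swap on Compound 2

The source may hold more compounds than are shown below. What is called first, only, known or untested is meant among the compounds shown, and "the series" means these compounds.

In a functional assay on K562 cells (Homo sapiens) for cytotoxicity, read by MTT assay, with a stated time of 24 h (a lower number here means a stronger inhibitor, a higher number a weaker inhibitor), compound 1 (`COc1ccc(/C=C2\CN(C)C/C(=C\c3ccccc3F)C2=O)cc1OC`) gives 18000 nM, compound 2 (`COc1cc(/C=C2\CN(C)C/C(=C\c3ccccc3F)C2=O)cc(OC)c1`) gives 6320 nM and compound 3 (`CN1C/C(=C\c2ccc(C#N)cc2)C(=O)/C(=C/c2ccccc2F)C1`) gives 2670 nM. Compound 2 therefore sits in the middle, with both gaps beyond the usual scatter. All three carry the 2-fluorophenyl group and differ elsewhere, so none of them shows directly what replacing that group does. Compound 4 (`COc1cc(/C=C2\CN(C)C/C(=C\c3ccc(Cl)c(Cl)c3)C2=O)cc(OC)c1`) has 3,4-dichlorophenyl in place of 2-fluorophenyl on a double-bonded chain carbon bound to a double-bonded ring carbon. The spread from compound 1 at 18000 nM to compound 3 at 2670 nM suggests that changes outside the shared core can move this number. A moderate expected step towards a lower number is a 2.1-fold lower number from compound 2 to compound 4 (0.32 log units; beyond the scatter). The estimate for compound 4 is 3000 nM, with an expected range of 800 nM to 10000 nM.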

Compound 4, half-maximal inhibitory concentration: 9490 nM
Compound 4: middle estimate off by 3.2-fold (0.50 log units), on the low side; measured number inside the range.
By their numbers in this assay, from the lowest: compound 3; then compounds 2, 4 and 1 (each within the scatter of the next, the first and the last beyond it).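

In this assay, within the data shown here, 3,4-dichlorophenyl in place of 2-fluorophenyl on this double-bonded chain carbon gives a 1.5-fold higher number from compound 2 to compound 4 (0.18 log units; within the scatter) and offers the first direct reading of this position. The two groups read alike here, so in this pair the fluorine is not needed to hold the number. Nothing measured here bears on the reason for this result. On these data alone, whether a phenyl ring carrying an amine or a carboxylic acid would move the number at this position remains open. So does whether the same swap reads alike in the setting of compound 1 or compound 3.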